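The compounds below may be only part of what the source reports. "The series", "measured", "known", "first", "only" and "open" are said of these compounds alone.

Compound 1 `COCCN1CC[C@H](C)Nc2cc(ccc2C(N)=O)-n2c(c(C)c3c2CC(C)(C)CC3=O)CC1=O` gives > 0.5 h as its value
Compound 2 `CC(=O)N1CCCc2c(C)c3c(n2-c2ccc(C(N)=O)c(c2)N[C@@H](C)C1)CC(C)(C)CC3=O` gives 0.183 h as its value

In an in vitro ADME assay on microsomes from liver (Rattus norvegicus) for metabolic stability (on this read-out higher numbers stand for a longer-lived compound and lower numbers for a shorter-lived compound), compound 1 stands at the limit of > 0.5 h in this assay, at which 1 of the 2 values shown sits, and that figure is a limit of the assay, not a number. Compound 2 gives 0.183 h as a plain number.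

Compound 3 `Cc1c2c(n3c1CC(=O)N(C)CC[C@H](C)Nc1cc-3ccc1C(N)=O)CC(C)(C)CC2=O` has not been measured yet. It differs from compound 1 in one place hydrogen in place of methoxymethyl on a saturated chain carbon bound to an amide-type nitrogen in a ring and the change puts hydrogen in place of methoxymethyl on a saturated chain carbon bound to an amide-type nitrogen in a ring. Cut one bond further out, the same difference reads 2-methoxyethyl to methyl.

Among the compounds with values here, no measured step shows what this change does in this assay so only a cautious expectation is possible: a small move toward a shorter-lived compound, not clearly beyond the usual scatter. The expected change is an at least 1.1-fold lower number from compound 1 to compound 3 (0.04 log units; that floor lies within the scatter) and it remains an estimate. For compound 3 the expected half-life is 0.45 h with an estimated range from 0.18 h to 1.2 h and the measurement may also come back as a limit.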

Compound 3, half-life: > 0.5 h
Compound 3 gave a limit, no number; the forecaster's own chance of this, stated with the estimate: 40%; middle value at least 1.1-fold (0.04 log units) from the limit.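

In this assay, compound 1 and compound 3 both return a limit of the assay rather than a number, so no step between them can be read: the limit of > 0.5 h in this assay, at which 2 of the 3 values shown sit.

The compounds shown leave open how long compound 1 and compound 3 actually last, and so whether going from 2-methoxyethyl to methyl changes the half-life at all.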